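Benzyl group exchange in the cyclohexyl amide pair

This account rests on a few compounds, and the source may have more. Where it says the series, first, only, none or still open, it means among the compounds named here.

Working notes on compound 2 and compound 3 in an assay on isolated protein with Bile acid receptor (Homo sapiens) as the target; a lower number here means that less compound is needed, a higher number that more compound is needed for the effect. Among the compounds with values here, compound 1 `COC(=O)/C=C/c1cccc(N(Cc2ccc(/C=C/C(=O)OC(C)(C)C)cc2)C(=O)NC(C)C)c1` is the only member with a full number: in this assay compound 1 gives 212 nM. Compound 2 `COC(=O)/C=C/c1cccc(N(Cc2ccccc2Br)C(=O)C2CCCCC2)c1` shares the methyl cinnamate part with compound 1 but differs elsewhere. In this assay compound 2 reports only a limit, > 1000 nM, so compound 2 stands at the limit of > 1000 nM in this assay, at which 1 of the 2 values shown sits, and its true value is not known. Compound 3 `COC(=O)/C=C/c1cccc(N(Cc2cc(OC)cc(OC)c2)C(=O)C2CCCCC2)c1` differs from compound 2 by 3,5-dimethoxyphenyl in place of 2-bromophenyl on a saturated chain carbon bound to an amide-type nitrogen. Within the data shown here, no measured step covers this exchange, and the pair of compound 1 and compound 2 gives no step of its own. The step from compound 2 to compound 3 in this assay is therefore expected to be a step that the limit leaves unreadable from compound 2 to compound 3, with nothing beyond the scatter anticipated. Compound 3 is estimated at about 1500 nM in this assay, in the range 400 nM to 8000 nM.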

Compound 3, half-maximal effective concentration: 606 nM
Estimate against measurement, compound 3: 2.5-fold (0.39 log units) above; low and high end bracket the measured number.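

In this assay compound 3 gives 606 nM as the first full number among the cyclohexyl amides shown, so this series can return a measurable value with 3,5-dimethoxyphenyl on a saturated chain carbon bound to an amide-type nitrogen. Within the data shown here, exchanging 2-bromophenyl for 3,5-dimethoxyphenyl at this place gives an at least 1.6-fold lower number from compound 2 to compound 3 (0.21 log units; that floor lies within the scatter) as the only reading of this change. On these data alone, the size of that step stays unknown because compound 2 reports only a limit: the limit of > 1000 nM in this assay, at which 1 of the 3 values shown sits.

As far as these compounds go, whether the exchange moves the number beyond the scatter remains open, as does whether either methoxy group alone accounts for the value of compound 3. A phenyl bearing a single methoxy group, a hydroxyl group or an amine at this place would also remain to be read in this assay.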